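Swapping the amide aryl group for a pyridine ring

The compounds below may be only part of what the source reports. "The series", "measured", "known", "first", "only" and "open" are said of these compounds alone.

Three related compounds have been measured in a physicochemical assay for lipophilicity, read by HPLC, in phosphate buffer, measured as chromatographic lipophilicity, at pH 7.4; a lower number here means a more polar compound, a higher number a more lipophilic compound. Compound 1 `COc1ccc2nc(C)cc(OCC(=O)Nc3cc(C)cc(C)c3)c2c1` gives 5.64 and stands lowest of the three. Compound 2 `Cc1cc(C)cc(NC(=O)COc2cc(C)nc3ccc(OC(F)(F)F)cc23)c1` gives 6.79, and compound 3 `COc1ccc2nc(C(F)(F)F)cc(OCC(=O)Nc3cc(C)cc(C)c3)c2c1` gives 7.02. Both measured steps go upward: a number 1.15 log units higher from compound 1 to compound 2 (beyond the scatter) and a number 1.38 log units higher from compound 1 to compound 3 (beyond the scatter).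

Compound 4 `COc1ccc2nc(C)cc(OCC(=O)Nc3cccnc3)c2c1` differs from compound 1 in one place: pyridin-3-yl in place of 3,5-dimethylphenyl on an amide-type nitrogen. For the measured compounds named here, neither measured step concerns this position or this kind of exchange, so no direct precedent exists; only the counted difference in atoms and the hydrogen-bond acceptor that enters can guide an expectation. Starting from compound 1, a clear downward move is expected for compound 4, an estimated a number 1.84 log units lower from compound 1 to compound 4 (beyond the scatter). Compound 4 is therefore expected to give 3.8, within a range from 3 to 4.6.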

Compound 4, distribution coefficient: 2.46
Compound 4: middle estimate off by 1.34 log units, on the high side; measured number outside the range, below it.
By their numbers in this assay, from the lowest: compound 4; then compound 1; then compounds 2 and 3 (each within the scatter of the next).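

On the amide-type nitrogen, this assay responds strongly: pyridin-3-yl in place of 3,5-dimethylphenyl gives a number 3.18 log units lower from compound 1 to compound 4 (beyond the scatter). This step runs opposite to the upward trifluoromethyl exchanges and is the largest shown. Nothing shown here explains its size.

This exchange changes the ring nitrogen and removes the methyl groups at once, and an unsubstituted phenyl group on the amide-type nitrogen would be needed to tell these two changes apart. On these data alone, whether pyridin-3-yl gives a similar step with the trifluoromethyl groups of compound 2 or compound 3 also remains open.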